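Swapping a Small Amide for a Methylphenyl Ring

A few compounds are considered here, and "the series" means these few. Any claim that something is new, unique, unknown or untested is made for them only; others in the source may bear on it.

Measured compounds:
Compound 1, `COc1ccc(Cl)cc1S(=O)(=O)Nc1cncc(C(=O)Nc2ccccc2)c1`, gives 310 nM in an assay on isolated protein for inhibition of alkaline phosphatase, tissue-nonspecific isozyme (Homo sapiens); on this read-out lower numbers stand for stronger inhibition and higher numbers for weaker inhibition.
Compound 2, `COc1ccc(Cl)cc1S(=O)(=O)Nc1cncc(-c2cccc(C)c2)c1`, gives 160 nM in this assay.
Compound 3, `CNC(=O)c1cncc(NS(=O)(=O)c2cc(Cl)ccc2OC)c1`, gives 109 nM in this assay.

Compound 3 holds the lowest of the three numbers. Its gap to compound 2 is within the scatter, so the two cannot be ranked, while the step of a 2.8-fold lower number from compound 1 to compound 3 (0.45 log units; beyond the scatter) lies beyond it. Compound 4, `COc1ccc(Cl)cc1S(=O)(=O)Nc1cncc(-c2ccc(C)cc2)c1`, changes one place on the shared core: 4-methylphenyl in place of methylcarbamoyl on an aromatic carbon.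

Among the measured compounds shown here, two measured steps bear on this. The step of a 1.5-fold lower number from compound 2 to compound 3 (0.17 log units; within the scatter) is the closest mirror, exchanging an aryl group for the small amide, and it stayed within the scatter. The step of a 1.9-fold lower number from compound 1 to compound 2 (0.29 log units; within the scatter), an aryl in place of a larger amide, also stayed within the scatter. Neither swap moved the number much, so no step beyond the scatter is expected in this assay; compound 4 is expected to sit close to compound 2, with a slightly higher number than compound 3.

Compound 4 is therefore estimated at 180 nM, with a range from 70 nM to 450 nM, an expected step of a 1.7-fold higher number from compound 3 to compound 4 (0.22 log units; within the scatter).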

Compound 4, half-maximal inhibitory concentration: 147 nM
Beside the measured number, compound 4's estimate is 1.2-fold (0.09 log units) above it; the measured number falls inside the stated range.
By their numbers in this assay, from the lowest: compounds 3, 4, 2 and 1 (each within the scatter of the next, the first and the last beyond it).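

In this assay, moving the methyl on the aryl group gives a 1.1-fold lower number from compound 2 to compound 4 (0.04 log units; within the scatter), so 3-methylphenyl and 4-methylphenyl cannot be told apart here, and the step of a 1.3-fold higher number from compound 3 to compound 4 (0.13 log units; within the scatter) shows that the all-carbon 4-methylphenyl, with no hydrogen-bond donor or acceptor, also cannot be separated from methylcarbamoyl. Among the compounds shown here, only the step of a 2.1-fold lower number from compound 1 to compound 4 (0.32 log units; beyond the scatter), which replaces phenylcarbamoyl with 4-methylphenyl, clears the scatter, and it is modest, so this position has so far tolerated quite different groups with little change in the number. No measurement shown here explains these numbers.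

From the compounds shown here alone, it remains open whether a phenyl ring carrying a carboxylic acid or an amine would also stay this close to compound 4. The effect of a longer chain in place of the methyl of 4-methylphenyl is equally unsettled.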